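The source may hold more compounds than are shown below. What is called first, only, known or untested is meant among the compounds shown, and "the series" means these compounds.

Of the compounds shown here, three that share one core have been measured in a functional assay on HT-29 cells (Homo sapiens) for inhibition, with a stated time of 72 h; on this read-out higher numbers stand for an effect only at larger amounts of compound and lower numbers for an effect already at smaller amounts. Compound 1 `CCOC(=O)Cn1c2ccccc2[n+]2nc3c(cc12)-c1cccc2cccc-3c12` gives 54000 nM, compound 2 `c1ccc(Cn2c3ccccc3[n+]3nc4c(cc23)-c2cccc3cccc-4c23)cc1` gives 1500 nM, and compound 3 `COC(=O)c1ccc(Cn2c3ccccc3[n+]3nc4c(cc23)-c2cccc3cccc-4c23)cc1` gives 24000 nM. On these numbers compound 3 stands second highest of three: its nearest neighbour is compound 1, and compound 2 lies far below it, as the step of a 16-fold higher number from compound 2 to compound 3 (1.20 log units; beyond the scatter) shows. The step of a 36-fold lower number from compound 1 to compound 2 (1.56 log units; beyond the scatter) was also large, whereas a 2.3-fold lower number from compound 1 to compound 3 (0.35 log units; beyond the scatter) was only modest.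

Compound 4 `NCCNC(=O)Cn1c2ccccc2[n+]2nc3c(cc12)-c1cccc2cccc-3c12` has not yet been measured in this assay. It differs from compound 3 by (2-aminoethyl)carbamoyl in place of 4-(methoxycarbonyl)phenyl on a saturated chain carbon bound to an aromatic nitrogen. Going by the values given here, the step that bears most on this change is the one between compound 1 and compound 3. In compound 1 the chain carbon bound to the aromatic nitrogen likewise carries a small carbonyl-containing group rather than a phenyl, and a 2.3-fold lower number from compound 1 to compound 3 (0.35 log units; beyond the scatter) was modest. Compound 4 is therefore expected to land near compound 1 and compound 3 rather than near compound 2, with the step of a 1.3-fold higher number from compound 3 to compound 4 (0.10 log units; within the scatter) expected to stay small. The estimate for compound 4 in this assay is 30000 nM, with a likely range from 8000 nM to 100000 nM.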

Compound 4, half-maximal effective concentration: > 100000 nM
Compound 4 was reported as a limit; the forecaster's own chance of this, stated with the estimate: 20%; middle value at least 3.3-fold (0.52 log units) away from the limit.
By their numbers in this assay, from the lowest: compound 2; then compound 3; then compound 1. At a limit, above all of these: compound 4.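

In this assay compound 4 gives > 100000 nM, which is a limit of the assay and not a number. Going by these compounds alone, with (2-aminoethyl)carbamoyl on this chain carbon, the read-out moves past what the earlier compounds reached, with an at least 4.1-fold higher number from compound 3 to compound 4 (0.61 log units; beyond the scatter) and an at least 66-fold higher number from compound 2 to compound 4 (1.82 log units; beyond the scatter), so this position tolerates even less than the ester of compound 1 had suggested when compared with the plain benzyl of compound 2. Swapping ethoxy for (2-aminoethyl)amino on the carbonyl carbon, however, gives an at least 1.8-fold higher number from compound 1 to compound 4 (0.26 log units; that floor lies within the scatter), so compound 4 cannot yet be firmly separated from compound 1, and the two groups without a ring both stay at the high end of the series, while compound 3 shows that a phenyl ring alone does not secure a low number.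

The compounds shown do not tell whether the amide or the terminal amine drives this result. A simple ethyl amide, a carboxylic acid on the same chain carbon, or a benzyl group carrying an amine on its ring would help to pull those two parts apart.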